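The compounds below may be only part of what the source reports. "The series", "measured", "known", "first", "only" and "open" are said of these compounds alone.

Compound 1, `COc1cccc(-c2ccc(C(=O)N[C@H](C)CCCc3cccnc3)cc2)c1`, gives 20 nM in an assay (Canis lupus familiaris) for binding affinity to platelet-activating factor receptor (Homo sapiens), read by radioligand binding; a lower number here means a stronger inhibitor, a higher number a weaker inhibitor. Compound 2, `CCCc1cc(C(=O)N[C@H](C)CCCc2cccnc2)ccc1-c1ccc(OC)c(OC)c1`, gives 50 nM in this assay, and compound 3, `CCCCc1cc(C(=O)N[C@H](C)CCCc2cccnc2)ccc1-c1ccc(OC)c(OC)c1`, gives 4 nM. Compound 3 and compound 2 differ by hydrogen in place of methyl on a saturated chain carbon, three bonds along the chain from an aromatic carbon, and the step is a 13-fold higher number from compound 3 to compound 2 (1.10 log units; beyond the scatter). The difference between the core of compound 1 and the core of compound 3 is not broken down here. Compound 4, `COc1cccc(-c2ccc(C(=O)NCCCCc3cccnc3)cc2)c1`, is still to be measured in this assay; it differs from compound 1 by hydrogen in place of methyl on a saturated chain carbon bound to an amide-type nitrogen and a saturated chain carbon. This is the same kind of change as that from compound 3 to compound 2, but its place differs: it sits on a saturated chain carbon bound to an amide-type nitrogen rather than three bonds along the chain from an aromatic carbon. Because the earlier step was a 13-fold higher number from compound 3 to compound 2 (1.10 log units; beyond the scatter), a weakening is expected from compound 1 to compound 4, estimated as a 3.0-fold higher number from compound 1 to compound 4 (0.48 log units; beyond the scatter), though a smaller one, since the place is not the same. Compound 4 is expected to give about 60 nM, between 15 nM and 250 nM.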

Compound 4, half-maximal inhibitory concentration: 280 nM
Estimate against measurement, compound 4: 4.7-fold (0.67 log units) below; the whole stated range lies below it.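

In this assay, hydrogen in place of methyl on a saturated chain carbon bound to an amide-type nitrogen and a saturated chain carbon gives a 14-fold higher number from compound 1 to compound 4 (1.15 log units; beyond the scatter). Set beside the earlier step, the two agree in size: the same change on two cores in this assay, a 13-fold higher number (1.10 log units; beyond the scatter) from compound 3 to compound 2 and a 14-fold higher number (1.15 log units; beyond the scatter) from compound 1 to compound 4, 1.1-fold (0.05 log units) apart, within the scatter of two such steps. This shows that losing one methyl cost about the same in these two cases, but each case rests on a single pair and the methyl sits in a different place in each, and it does not show that the step's size would hold at another place or on a further core. The compounds shown leave open what an ethyl group or a longer chain would give on that saturated chain carbon, where only methyl and hydrogen appear.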